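Chalcone-pyrazole series: halogen swap on the aryl ketone

This account rests on a few compounds, and the source may have more. Where it says the series, first, only, none or still open, it means among the compounds named here.

Within the data shown here, compound 1 `COc1ccc(-c2cc(/C=C/C(=O)c3ccc(OC)c(OC)c3)[nH]n2)cc1` and compound 2 `COc1cc(-c2cc(/C=C/C(=O)c3ccc(Cl)c(Cl)c3)[nH]n2)cc(OC)c1OC` are the two measured members. In a functional assay on M14 cells (Homo sapiens) for cytotoxicity, read by sulforhodamine B assay, with a stated time of 48 h, tested at 10 uM (on this read-out higher numbers stand for a weaker effect at the one concentration tested and lower numbers for a stronger effect), compound 1 gives -42%, while compound 2 gives 61%, the higher of the two numbers, with compound 1 lying beyond the scatter below it. Compound 3 `COc1cc(-c2cc(/C=C/C(=O)c3ccc(F)c(F)c3)[nH]n2)cc(OC)c1OC` has not been measured; it differs from compound 2 by 3,4-difluorophenyl in place of 3,4-dichlorophenyl on a carbonyl carbon. Among the measured compounds shown here, no measured pair shows this change, so only a small step, likely none beyond the scatter, is expected: compound 3 is estimated at 50%, within 10% to 90%, an expected step of a number 11 percentage points lower from compound 2 to compound 3 (beyond the scatter).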

Compound 3, a percentage reported as activity, at one concentration (the size of the read-out at that concentration, not a potency): 3%
The estimate for compound 3 lay 47 percentage points above the measured number; measured number below the stated range.
By their numbers in this assay, from the lowest: compound 1; then compound 3; then compound 2.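

On a carbonyl carbon, the exchange of halogens on the aryl group is far from silent: in this assay 3,4-difluorophenyl in place of 3,4-dichlorophenyl gives a number 58 percentage points lower from compound 2 to compound 3 (beyond the scatter) even though the two groups match in heavy-atom count, hydrogen-bond donors, hydrogen-bond acceptors and net charge. Among these compounds, this is the first single-place comparison, and it shows that this position responds strongly to the identity of the halogen. Nothing measured here accounts for the step.

Open, on these data alone, is how a 3,4-dibromophenyl group or an unsubstituted phenyl would read out at this position. Also open, as far as these compounds go, is whether the same exchange carries the same step on the core of compound 1.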